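Oxolan-2-yl in place of oxolan-3-yl: compound 4 awaited

A few compounds are considered here, and "the series" means these few. Any claim that something is new, unique, unknown or untested is made for them only; others in the source may bear on it.

- compound 1 `CCCC(O)CC(=O)O[C@H](CC=C(C)C)C1=CC(=O)c2c(O)ccc(O)c2C1=O`: > 100000 nM, a limit of the assay
- compound 2 `CC[C@](C)(O)CC(=O)O[C@H](CC=C(C)C)C1=CC(=O)c2c(O)ccc(O)c2C1=O`: 20500 nM
- compound 3 `CC(C)=CC[C@@H](OC(=O)C1CCOC1)C1=CC(=O)c2c(O)ccc(O)c2C1=O`: 47500 nM

In a functional assay on DU-145 cells (Homo sapiens) for cytotoxicity, read by MTT assay (on this read-out higher numbers stand for weaker inhibition and lower numbers for stronger inhibition), compound 3 holds the higher of the two actual numbers, with a 2.3-fold higher number from compound 2 to compound 3 (0.36 log units; beyond the scatter). Compound 4 `CC(C)=CC[C@@H](OC(=O)C1CCCO1)C1=CC(=O)c2c(O)ccc(O)c2C1=O` differs from it by one change: oxolan-2-yl in place of oxolan-3-yl on a carbonyl carbon.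

Within the data shown here, no measured step makes this change. The closest evidence comes from exchanges of the whole group on the carbonyl carbon. These are a 2.3-fold higher number from compound 2 to compound 3 (0.36 log units; beyond the scatter), which is modest, and an at least 2.1-fold lower number from compound 1 to compound 3 (0.32 log units; beyond the scatter), which rests on a limit. Since the new group has the same atoms as the old, a step no larger than these is expected, with no direction favoured. The expected result is a 1.2-fold lower number from compound 3 to compound 4 (0.07 log units; within the scatter). For compound 4 the estimated value is 40000 nM, with an expected range of 15000 nM to 100000 nM.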

Compound 4, half-maximal inhibitory concentration: 10500 nM
The estimate for compound 4 lay 3.8-fold (0.58 log units) above the measured number; the measured number lies below the stated range.
By their numbers in this assay, from the lowest: compounds 4 and 2 (each within the scatter of the next); then compound 3. At a limit, above all of these: compound 1.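

In this assay, the same atoms joined differently on the carbonyl carbon are enough to shift the result: oxolan-2-yl in place of oxolan-3-yl gives a 4.5-fold lower number from compound 3 to compound 4 (0.66 log units; beyond the scatter). Set against 2-hydroxy-2-methylbutyl, the same group gives a 2.0-fold lower number from compound 2 to compound 4 (0.29 log units; within the scatter), so these two groups cannot be told apart here. Set against 2-hydroxypentyl, it gives an at least 9.5-fold lower number from compound 1 to compound 4 (0.97 log units; beyond the scatter), which is only a bound because compound 1 stands at a limit: the limit of > 100000 nM in this assay, at which 1 of the 4 values shown sits.

The compounds shown leave open whether a pyrrolidin-2-yl ring, with an amine in place of the ring oxygen, or a larger oxan-2-yl ring on the same carbonyl carbon would match compound 4.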